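A second methoxy on the aryl ring of compound 2

A few compounds are considered here, and "the series" means these few. Any claim that something is new, unique, unknown or untested is made for them only; others in the source may bear on it.

Measured so far:
Compound 1 `O=C(N/N=C/c1ccc(Cl)cc1)c1cccnc1Nc1cccc(C(F)(F)F)c1` gives 48.5% in a functional assay on the whole organism (strain Wistar) for inhibition, with Rattus norvegicus as the target, read by paw edema, with a stated time of 3 h, at a dose of 10 mg/kg by the intraperitoneal route; on this read-out lower numbers stand for less inhibition and higher numbers for more inhibition at the one dose given (going by the name of the read-out).
Compound 2 `COc1ccc(/C=N/NC(=O)c2cccnc2Nc2cccc(C(F)(F)F)c2)cc1` gives 26.5% in this assay.

Among the measured compounds shown here, compound 2 stands lowest of the two numbers; its nearest neighbour is compound 1, and the one measured step, a number 22 percentage points lower from compound 1 to compound 2 (beyond the scatter), came with methoxy in place of chloro on an aromatic carbon. Compound 3 `COc1ccc(/C=N/NC(=O)c2cccnc2Nc2cccc(C(F)(F)F)c2)cc1OC` differs from compound 2 by methoxy in place of hydrogen on an aromatic carbon, which read one bond further out is 4-methoxyphenyl to 3,4-dimethoxyphenyl. For the measured compounds named here, no measured step shows this same change; the step from compound 1 to compound 2 is the only one that bears on it, and only loosely, since it concerns a different exchange. With so little to go on, compound 3 is expected to land close to compound 2, giving a step of a number 1.5 percentage points lower from compound 2 to compound 3 (within the scatter) that is likely within the scatter. The estimate for compound 3 is 25%, with a range from 10% to 42%.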

Compound 3, a percentage reported as inhibition, in the whole organism at one dose (the size of the read-out at that dose, not a potency): 44%
Estimate against measurement, compound 3: 19 percentage points below, outside the stated range (above it).
By their numbers in this assay, from the lowest: compound 2; then compounds 3 and 1 (each within the scatter of the next).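

In this assay a methoxy on the aromatic carbon ortho to a methoxy group, which turns 4-methoxyphenyl into 3,4-dimethoxyphenyl, makes a clear difference (a number 17.5 percentage points higher from compound 2 to compound 3 (beyond the scatter)). This shows that the ring carbon holding only hydrogen in compound 2 is not a silent position, and that adding a group there can raise the number. The 3,4-dimethoxyphenyl and 4-chlorophenyl rings cannot be told apart here (a number 4.5 percentage points lower from compound 1 to compound 3 (within the scatter)), and nothing available explains why this carbon matters.

On these data alone, whether methoxy itself is needed stays open, as a hydroxyl, an amine or a longer ethoxy chain on the same carbon would show. Also open, as far as these compounds go, is whether a methoxy on this carbon would change the number in the same way in compound 1.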